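This account rests on a few compounds, and the source may have more. Where it says the series, first, only, none or still open, it means among the compounds named here.

Of the compounds shown here, three have been measured in an ADME assay on HUVEC cells (Homo sapiens) for inhibition, read by CCK-8 assay, with a stated time of 24 h, in the presence of a further agent that is not named here; a higher number here means a weaker inhibitor, a lower number a stronger inhibitor. Compound 1 `O=C1Nc2ccccc2/C1=C/c1ccc(-c2cn(-c3ccccc3F)nn2)cc1` gives 19300 nM, compound 2 `Cc1cccc(-n2cc(-c3ccc(/C=C4\C(=O)Nc5ccc(F)cc54)cc3)nn2)c1` gives 9880 nM, and compound 3 `Cc1ccc(-n2cc(-c3ccc(/C=C4\C(=O)Nc5ccc(F)cc54)cc3)nn2)cc1` gives 13800 nM. Compound 3 is separated from neither of the other two by more than the scatter.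

Compound 4 `O=C1Nc2ccc(F)cc2/C1=C/c1ccc(-c2cn(-c3ccccc3F)nn2)cc1` keeps the core of compound 3 and carries 2-fluorophenyl in place of 4-methylphenyl on an aromatic nitrogen. Among the compounds with values here, the one measured step at this place is a 1.4-fold higher number from compound 2 to compound 3 (0.15 log units; within the scatter), and it exchanges one methylphenyl for another, so it only partly bears on a change to 2-fluorophenyl. Within the data shown here, compound 1 already carries the 2-fluorophenyl group, though on a different core, and its 19300 nM offers the only other guide. Neither observation points to a large shift, so no step beyond the scatter is expected in this assay. The expected change is a 1.0-fold higher number from compound 3 to compound 4 (0.01 log units; within the scatter). For compound 4 the estimate is 14000 nM, with an expected range from 7000 nM to 28000 nM.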

Compound 4, half-maximal inhibitory concentration: 14400 nM
Compound 4: middle estimate off by 1.0-fold (0.01 log units), on the low side; low and high end bracket the measured number.
By their numbers in this assay, from the lowest: compounds 2, 3, 4 and 1 (each within the scatter of the next).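

In this assay, the 2-fluorophenyl group on the aromatic nitrogen gives a 1.0-fold higher number from compound 3 to compound 4 (0.02 log units; within the scatter) and a 1.5-fold higher number from compound 2 to compound 4 (0.16 log units; within the scatter), so on this core the position now holds a fluorinated phenyl as well as two methylphenyl groups, and every exchange among them stays within the scatter. Within the data shown here, the new compound also gives the first reading at a second place, fluoro in place of hydrogen on an aromatic carbon, with a 1.3-fold lower number from compound 1 to compound 4 (0.13 log units; within the scatter), and this step too stays within the scatter. Nothing available here explains why these numbers lie so close together.

The compounds shown leave open whether any change at either place can move the number beyond the scatter. On the phenyl ring they cover only methyl and fluoro, so an amine, a carboxylic acid or a longer chain there remains an open case.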